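Swapping the ethoxycarbonyl for isobutoxycarbonyl on compound 1

The compounds below may be only part of what the source reports. "The series", "measured", "known", "first", "only" and "open" are said of these compounds alone.

compound 1 `CCOC(=O)c1cc(N2C(=O)C3=C(CCCC3)C2=O)c(F)cc1Cl`: 57.5 nM
compound 2 `CCOC(=O)c1cc(N2C(=O)C3=C(CCCC3)C2=O)ccc1Cl`: 1910 nM
compound 3 `CCCCOC(=O)c1cc(N2C(=O)C3=C(CCCC3)C2=O)ccc1Cl`: 6310 nM

All three compounds were tested in a functional assay on the whole organism for inhibition, with Scenedesmus acutus as the target; a lower number here means a stronger inhibitor, a higher number a weaker inhibitor. Among them compound 1 has the lowest number, 57.5 nM, which makes it the strongest inhibitor of the three. Compound 4 `CC(C)COC(=O)c1cc(N2C(=O)C3=C(CCCC3)C2=O)c(F)cc1Cl` has not yet been measured. It keeps the core of compound 1 and changes only the chain: isopropyl in place of methyl on a saturated chain carbon bound to an oxygen next to a carbonyl group. The same difference can be read as ethoxycarbonyl to isobutoxycarbonyl.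

Two measured steps are available. The large one, a 33-fold higher number from compound 1 to compound 2 (1.52 log units; beyond the scatter), swaps hydrogen in place of fluoro on an aromatic carbon. It says little here, since compound 4 keeps the fluoro of compound 1. The closer guide is a 3.3-fold higher number from compound 2 to compound 3 (0.52 log units; beyond the scatter), a modest step that also extends this chain, with ethyl in place of hydrogen on a saturated chain carbon. Within the data shown here, it is a single step, taken on compounds without the fluoro, and no isobutyl compound has been measured, so the guide is rough. A similar modest rise is therefore expected in this assay, and the estimated step is a 3.0-fold higher number from compound 1 to compound 4 (0.47 log units; beyond the scatter). For compound 4 the expected value is 170 nM, with an estimated range from 60 nM to 500 nM.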

Compound 4, half-maximal inhibitory concentration: 100 nM
Estimate against measurement, compound 4: 1.7-fold (0.23 log units) above; the measured number falls inside the stated range.
By their numbers in this assay, from the lowest: compounds 1 and 4 (each within the scatter of the next); then compound 2; then compound 3.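

In this assay, a larger chain at this position is tolerated on the fluoro-bearing compounds: replacing ethoxycarbonyl with isobutoxycarbonyl gives a 1.7-fold higher number from compound 1 to compound 4 (0.24 log units; within the scatter), so the two compounds cannot be told apart. Among these compounds, the only earlier chain step, taken on compounds without the fluoro, was a 3.3-fold higher number from compound 2 to compound 3 (0.52 log units; beyond the scatter), and it lay beyond the scatter, so a longer chain on the ester does not bring a measurable loss in every setting. No measurement offers a reason for this result.

The two chain steps differ both in the chain itself, isobutyl against butyl, and in the presence of the fluoro, so these compounds cannot show which of those differences matters; an isobutyl ester without the fluoro or a butyl ester with it would be needed to separate them. From the compounds shown here alone, it also remains open how far this tolerance extends, for instance to a longer chain such as octyl, or whether the ester can give way to a carboxylic acid or an amide.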